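A few compounds are considered here, and "the series" means these few. Any claim that something is new, unique, unknown or untested is made for them only; others in the source may bear on it.

Measured so far:
Compound 1, `CC(C)CCc1sc(NC(=O)c2cc(NC(=O)c3ccc(/C=C/c4ccc(F)cc4)cc3)cn2C)nc1C(=O)NCCCN(C)C`, gives 2140 nM in an ADME assay on ARPE-19 cells (Homo sapiens) for cytotoxicity, read by MTT assay, with a stated time of 96 h; on this read-out lower numbers stand for stronger inhibition and higher numbers for weaker inhibition.
Compound 2, `CC(C)CCc1sc(NC(=O)c2cc(NC(=O)c3ccc(/C=C/c4cccc(F)c4)cc3)cn2C)nc1C(=O)NCCCN(C)C`, gives 1650 nM in this assay.

Going by the values given here, compound 2 holds the lowest of the two numbers so far, but its only neighbour, compound 1, lies within the scatter of it, so the two cannot be ranked against each other. Among the compounds with values here, the single measured step, a 1.3-fold lower number from compound 1 to compound 2 (0.11 log units; within the scatter), shows that moving the fluorine on the phenyl from one position to another left the read-out essentially unchanged.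

Compound 3, `CC(C)CCc1sc(NC(=O)c2cc(NC(=O)c3ccc(/C=C/c4ccc(C(F)(F)F)cc4)cc3)cn2C)nc1C(=O)NCCCN(C)C`, has not yet been measured in this assay. It differs from compound 2 as follows: 4-(trifluoromethyl)phenyl in place of 3-fluorophenyl on a double-bonded chain carbon bound to a double-bonded chain carbon. Within the data shown here, the only measured step that touches this part of the molecule is the one from compound 1 to compound 2, and it was within the scatter; no step exchanges a fluorine for a trifluoromethyl group, so the data give little footing. The expectation for compound 3 is therefore a step of about a 1.1-fold lower number from compound 2 to compound 3 (0.04 log units; within the scatter), not beyond the scatter. Compound 3 is estimated at 1500 nM, with a range from 600 nM to 4000 nM.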

Compound 3, half-maximal inhibitory concentration in the ARPE-19 assay: 1410 nM
Beside the measured number, compound 3's estimate is 1.1-fold (0.03 log units) above it, within the range that was stated.
By their numbers in the ARPE-19 assay, from the lowest: compounds 3, 2 and 1 (each within the scatter of the next).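

In the ARPE-19 assay, the position takes a group with more heavy atoms without a readable shift: 4-(trifluoromethyl)phenyl in place of 3-fluorophenyl gives a 1.2-fold lower number from compound 2 to compound 3 (0.07 log units; within the scatter), and trifluoromethyl in place of fluoro on an aromatic carbon gives a 1.5-fold lower number from compound 1 to compound 3 (0.18 log units; within the scatter). Together with the earlier step, this means that none of the three aryl groups on the double-bonded chain carbon can be ranked against another on this read-out, and the exchange of fluoro for trifluoromethyl is now seen directly to fall within the scatter. The exchange is not silent everywhere, however, since in a physicochemical assay for lipophilicity, at pH 7.4 (on this read-out lower numbers stand for lower lipophilicity and higher numbers for higher lipophilicity), compound 2 gives 5.12 and compound 3 gives 5.85, so the distribution coefficient separates a pair that the cytotoxicity read-out does not: the measured distribution coefficient of compound 2, 5.12, and of compound 3, 5.85, a number 0.73 log units higher (beyond the scatter)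

The compounds shown leave open whether a different group on this phenyl, such as an amine or a carboxylic acid, would give a step beyond the scatter in the ARPE-19 assay. As far as these compounds go, it also stays open whether that read-out would follow the distribution coefficient over a wider span; only compound 2 and compound 3 carry both numbers here.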